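The compounds below may be only part of what the source reports. "The series", "measured", "known", "first", "only" and "open" are said of these compounds alone.

Compound 2, `COc1ccc(NC(=O)N[C@H]2CC[C@H](Oc3ccc(F)cc3)CC2)cc1`, is a urea that joins a 4-methoxyphenyl group to a cyclohexyl ring bearing a 4-fluorophenyl ether. In a functional assay on CRL2813 cells (Homo sapiens) for cytotoxicity, read by sulforhodamine B assay, with a stated time of 5 days (a higher number here means a weaker inhibitor, a lower number a stronger inhibitor), compound 2 gives > 20000 nM, which is a limit of the assay and not a measured number, as shown by the limit of > 20000 nM in this assay, at which 1 of the 3 values shown sits. Two measured compounds share the same core but carry a trifluoromethyl-bearing phenyl on the amide-type nitrogen and a different ether: compound 1, `O=C(Nc1cccc(C(F)(F)F)c1)N[C@H]1CC[C@H](Oc2ccc(Cl)cc2)CC1`, gives 2000 nM, and compound 3, `O=C(Nc1cccc(C(F)(F)F)c1)N[C@H]1CC[C@H](Oc2ccc(C(F)(F)F)cc2)CC1`, gives 460 nM. Going by the values given here, the only measured step, a 4.3-fold lower number from compound 1 to compound 3 (0.64 log units; beyond the scatter), alters the ether side, not the aryl on the amide-type nitrogen, so no measured step bears directly on the present change.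

Compound 4, `O=C(Nc1cccc(I)c1)N[C@H]1CC[C@H](Oc2ccc(F)cc2)CC1`, differs from compound 2 in one place: 3-iodophenyl in place of 4-methoxyphenyl on an amide-type nitrogen. The ether of compound 2 is kept, while the aryl moves toward the substituted type seen in compounds 1 and 3, which gave numbers rather than limits. Compound 4 is therefore expected to give a measurable value, estimated at 5000 nM with a range from 1500 nM to 20000 nM. That estimate means an expected at least 4.0-fold lower number from compound 2 to compound 4 (0.60 log units; beyond the scatter).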

Compound 4, half-maximal inhibitory concentration: 5200 nM
For compound 4 the middle estimate is 1.0-fold (0.02 log units) below the measured one, within the range that was stated.
By their numbers in this assay, from the lowest: compound 3; then compound 1; then compound 4. At a limit, above all of these: compound 2.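

Exchanging 4-methoxyphenyl for 3-iodophenyl on the amide-type nitrogen, with the 4-fluorophenyl ether kept, gives an at least 3.8-fold lower number from compound 2 to compound 4 (0.58 log units; beyond the scatter) in this assay. This shows that the aryl group at this place can alone shift the number beyond the scatter, which the earlier step on the ether side could not show. The result for compound 2 is a limit of the assay and not a number, so the full size of this step stays unknown: the limit of > 20000 nM in this assay, at which 1 of the 4 values shown sits.

The step changes both the substituent and its place on the phenyl ring, and the compounds shown cannot separate these two changes. From the compounds shown here alone, a 3-methoxyphenyl or 4-iodophenyl group on this nitrogen could help to separate them, while the result with an amine or a carboxylic acid on the ring also remains open.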